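Swapping a piperidine amide for a fluorophenyl amide

The source may report more compounds than this note shows. Statements on the series, on what has been measured and on what is new or still open speak of the compounds shown alone.

Compound 1 `COc1ccc(-c2cnc(NC(=O)C3CCNCC3)n2C)cc1` is an imidazole-based amide whose carbonyl carries a piperidin-4-yl group. In a toxicity assay on THP-1 cells (Homo sapiens) for inhibition (a higher number here means that more compound is tolerated, a lower number that less compound is tolerated), compound 1 reaches only a limit, > 100000 nM, so no finite number is known for it. Two other amides give a sense of the range. Compound 2 `Cn1cc(-c2ccccc2)nc1NC(=O)c1ccc(F)cc1` also sits at a limit, > 50000 nM, in this assay. For the measured compounds named here, compound 3 `O=C(Nc1ncc(-c2ccccc2)o1)c1ccc(F)cc1` gives 17000 nM in this assay, the only finite value among the three. Compound 4 `COc1ccc(-c2cnc(NC(=O)c3cccc(F)c3)n2C)cc1` is to be measured next. It differs from compound 1 in one place: 3-fluorophenyl in place of piperidin-4-yl on a carbonyl carbon. Going by the values given here, no measured pair that differs in a single position is available, so the size of this step cannot be read from the data. Since compound 2, which carries an aryl amide on the same kind of core, stands at the limit of > 50000 nM in this assay, at which 1 of the 3 values shown sits, the expectation is that compound 4 stays tolerated at a high concentration, with at most a modest decrease. The step of an at least 1.6-fold lower number from compound 1 to compound 4 (0.22 log units; that floor lies within the scatter) is an estimate only. Compound 4 is expected to give about 60000 nM, within 15000 nM to 200000 nM.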

Compound 4, half-maximal cytotoxic concentration: > 100000 nM
Compound 4: only a limit was reported; the forecaster's own chance of this, stated with the estimate: 55%; at least 1.6-fold (0.22 log units) between middle value and limit.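

Compound 4 reaches only a limit, > 100000 nM, in this assay. Compound 1 also stands at a limit, so the step between compound 1 and compound 4 cannot be read. The compounds shown leave open whether 3-fluorophenyl in place of piperidin-4-yl changes tolerance at all.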